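The compounds below may be only part of what the source reports. "The series", "measured", "known", "first", "only" and "open" are said of these compounds alone.

Series notes, cytotoxicity on the shared core of compound 2 `CNC(=O)c1cc(Oc2ccc(NC(=O)c3nn(-c4ccc(C)cc4)c(=O)cc3C)cc2F)ccn1`. Among the measured compounds shown here, in a functional assay on A549 cells (Homo sapiens) for cytotoxicity, read by MTT assay, with a stated time of 72 h (on this read-out higher numbers stand for weaker inhibition and lower numbers for stronger inhibition), compound 2 gives 11500 nM, the only numerical value in the set so far. One further value is recorded as a limit. That limit belongs to compound 1 `CNC(=O)c1cc(Oc2ccc(NC(=O)c3nn(-c4ccccc4OC(F)(F)F)c(=O)cc3C)cc2F)ccn1`, which in this assay gives > 40000 nM, a limit of the assay rather than a number; see also (the limit of > 40000 nM in this assay, at which 1 of the 2 values shown sits). For the measured compounds named here, the one measured step, an at least 3.4-fold lower number from compound 1 to compound 2 (0.54 log units; beyond the scatter), reaches beyond the scatter.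

Compound 3 `CNC(=O)c1cc(Oc2ccc(NC(=O)c3nn(-c4ccccc4F)c(=O)cc3C)cc2F)ccn1` is next: 2-fluorophenyl in place of 4-methylphenyl on an aromatic nitrogen. It bears on the measured step only loosely, as the step from compound 1 to compound 2 exchanged a 2-(trifluoromethoxy)phenyl for a 4-methylphenyl, whereas here a 2-fluorophenyl enters. A step of at most modest size in this assay is expected, in either direction, or none beyond the scatter. The value of compound 3 is therefore estimated at 20000 nM, within 6000 nM to 60000 nM, which would mean a step of a 1.7-fold higher number from compound 2 to compound 3 (0.24 log units; within the scatter).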

Compound 3, half-maximal inhibitory concentration: > 40000 nM
Compound 3: only a limit was reported (the forecaster's own chance of this, stated with the estimate: 30%); middle value at least 2.0-fold (0.30 log units) away from the limit.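

Notes on the aromatic nitrogen: in this assay, 2-fluorophenyl in place of 4-methylphenyl gives an at least 3.4-fold higher number from compound 2 to compound 3 (0.54 log units; beyond the scatter). The two groups match in heavy-atom count and in hydrogen-bond donors and acceptors, so a change that leaves these counts the same still moves the read-out beyond the scatter at this position. Compound 3 has a limit of the assay rather than a number, as does compound 1, so the step between these two cannot be read: the limit of > 40000 nM in this assay, at which 2 of the 3 values shown sit.

On these data alone, what a 4-fluorophenyl or a 2-methylphenyl would give here remains open, and with it whether the step follows the substituent itself or its place on the phenyl ring. The same question stands for plain phenyl and for a phenyl bearing an amine or a carboxylic acid.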